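The source may report more compounds than this note shows. Statements on the series, on what has been measured and on what is new or still open speak of the compounds shown alone.

Working notes on the series. Compound 2 `Nc1cc(N)c2nc(-c3ccccc3)c(Oc3ccc(F)cc3)nc2c1` carries a 4-fluorophenoxy group on the shared core; in a functional assay on PC-3 cells (Homo sapiens) for inhibition, read by sulforhodamine B assay, with a stated time of 48 h (a higher number here means a weaker inhibitor of growth, a lower number a stronger inhibitor of growth), compound 2 gives 8320 nM. Compound 1 `Nc1cc(N)c2nc(-c3ccccc3)c(Oc3ccc(Cl)c(Cl)c3)nc2c1` carries a 3,4-dichlorophenyl on the oxygen instead, and in this assay compound 1 gives 3020 nM. Of the two numbers measured so far, compound 2 stands at the higher one; the only step shown, a 2.8-fold higher number from compound 1 to compound 2 (0.44 log units; beyond the scatter), is what separates it from compound 1.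

Compound 3 `Nc1cc(N)c2nc(-c3ccccc3)c(Sc3ccc(F)cc3)nc2c1` is the unmeasured member. The change from compound 2 is (4-fluorophenyl)sulfanyl in place of 4-fluorophenoxy on an aromatic carbon: the aryl group is kept, and the atom joining it to the core is exchanged. No measured step bears directly on this change; the one step shown, a 2.8-fold higher number from compound 1 to compound 2 (0.44 log units; beyond the scatter), alters the substituents on the aryl ring while the oxygen is kept, and gives no guide to exchanging oxygen for sulfur. The expectation for compound 3 in this assay is therefore a step of a 1.1-fold lower number from compound 2 to compound 3 (0.05 log units; within the scatter), that is, no shift beyond the scatter in either direction, with wide uncertainty. On that basis compound 3 is estimated at 7500 nM, with a range from 2500 nM to 22000 nM.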

Compound 3, concentration for 50% growth inhibition: < 100000 nM
Compound 3 ended at the assay's limit; the forecaster's own chance of this, stated with the estimate: 5%; the middle value does not contradict the limit.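

In this assay compound 3 gives < 100000 nM, which is a limit of the assay and not a number. Within the data shown here, no step to compound 3 from compound 2 or from compound 1 can be read from it. The compounds shown leave open whether (4-fluorophenyl)sulfanyl in place of 4-fluorophenoxy on the shared core shifts growth inhibition at all, in either direction.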